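Shortening an alkoxy chain in a series free of cytotoxicity

This account rests on a few compounds, and the source may have more. Where it says the series, first, only, none or still open, it means among the compounds named here.

Compound 1 `CCCCCCCCSc1nc(N)nc2c1ncn2/C=C1/CC1(CO)CO` gives in an ADME assay on MOLT-3 cells (Homo sapiens) for cytotoxicity, with a stated time of 7 days (on this read-out lower numbers stand for higher toxicity in this test and higher numbers for lower toxicity in this test), only a limit of the test, > 20000 nM.
Compound 2 `CCCCCCSc1nc(N)nc2c1ncn2/C=C1/CC1(CO)CO` gives in this assay only a limit of the test, > 20000 nM.
Compound 3 `CCCCCCOc1nc(N)nc2c1ncn2/C=C1/CC1(CO)CO` gives in this assay only a limit of the test, > 20000 nM.

The step that the two limits leave unreadable from compound 1 to compound 2 is made by the change (hydrogen in place of ethyl on a saturated chain carbon, six bonds along the chain from a sulfur). Compound 3 has a different side chain on the shared core, the difference being (hexyloxy in place of octylsulfanyl on an aromatic carbon); the step that the two limits leave unreadable from compound 1 to compound 3 and the step that the two limits leave unreadable from compound 2 to compound 3 are both hidden by the limits. Compound 4 `CCCCOc1nc(N)nc2c1ncn2/C=C1/CC1(CO)CO` arises from compound 3 by the change (hydrogen in place of ethyl on a saturated chain carbon, four bonds along the chain from an oxygen on an aromatic ring), the same kind of change as that from compound 1 to compound 2, but now four bonds along the chain from an oxygen on an aromatic ring rather than six bonds from a sulfur. For compound 4 the expected step is a step that the limit leaves unreadable from compound 3 to compound 4, resting on the limit of > 20000 nM in this assay, at which 3 of the 3 values shown sit, and on the unreadable a step that the two limits leave unreadable from compound 1 to compound 2. Compound 4 is therefore estimated at 25000 nM, between 10000 nM and 60000 nM.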

Compound 4, half-maximal cytotoxic concentration: > 20000 nM
Compound 4: a limit, no number (the forecaster's own chance of this, stated with the estimate: 85%); the middle value is on the limit's open side.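

Compound 4 gives only a limit, as do compound 1, compound 2 and compound 3, so no step to compound 4 can be read: the limit of > 20000 nM in this assay, at which 4 of the 4 values shown sit.

The compounds shown leave open what concentration, if any, would harm the cells in this assay, and whether chain length matters there.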